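Triazole in place of the terminal acid: expected binding

A few compounds are considered here, and "the series" means these few. Any claim that something is new, unique, unknown or untested is made for them only; others in the source may bear on it.

Of the compounds shown here, two have been measured in an assay on isolated protein for inhibition of leukotriene B4 receptor 1 (Homo sapiens), tested at 10 uM; a lower number here means less inhibition, a higher number more inhibition at the concentration tested (going by the name of the read-out). Compound 1 `CCc1cc(C(C)=O)c(O)cc1OCCCCCC(C)(C)C(=O)O` gives 104%, the higher of the two numbers recorded. Compound 2 `C=CCc1cc(C(C)=O)c(O)cc1OCCCCCC(C)(C)O` gives 98%, a number that lies within the scatter of the value for compound 1, so the two cannot be ordered. Among the measured compounds shown here, compound 2 differs from compound 1 in more than one place, and no single step between them is available; what is known is only that the two numbers lie within the scatter of each other at the concentration tested.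

Compound 3 `CCc1cc(C(C)=O)c(O)cc1OCCCCCn1cncn1` has not yet been measured. It differs from compound 1 in one place: 1H-1,2,4-triazol-1-yl in place of 1-carboxy-1-methylethyl on a saturated chain carbon, five bonds along the chain from an oxygen on an aromatic ring. Because compound 2 gives 98% without carrying the carboxy group of compound 1, the series does not seem to depend on that group alone for a high read-out, though two compounds are too few for a firm pattern. The expected step of a number 19 percentage points lower from compound 1 to compound 3 (beyond the scatter) is downward and of moderate size, somewhat beyond the scatter. Compound 3 is estimated to give 85%, with a range from 55% to 105%.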

Compound 3, a percentage reported as inhibition, at one concentration (the size of the read-out at that concentration, not a potency): 82%
For compound 3 the middle estimate is 3 percentage points above the measured one, within the range that was stated.
By their numbers in this assay, from the lowest: compound 3; then compounds 2 and 1 (each within the scatter of the next).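

In this assay, among the compounds shown here, the change from 1-carboxy-1-methylethyl to 1H-1,2,4-triazol-1-yl on a saturated chain carbon, five bonds along the chain from an oxygen on an aromatic ring, gives the first readable step at this position: a number 22 percentage points lower from compound 1 to compound 3 (beyond the scatter). The read-out at this position therefore responds to the group placed there, yet compound 3, which has no carboxylic acid, still gives 82% at the single concentration tested. No measurement available on the series accounts for the direction or size of this step.

Still open, on these data alone, is whether the step follows from removing the carboxylic acid, from removing the branched carbon that carries it, or from introducing the triazole, and a plain carboxymethyl group, an imidazole or a tetrazole at the same place would begin to separate these. Also open, as far as these compounds go, is how the step would look as a potency, since a read-out at one concentration does not give one, and whether a longer chain carrying the triazole would change the number.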